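From methoxy to isopropoxy, starting from a limit

A few compounds are considered here, and "the series" means these few. Any claim that something is new, unique, unknown or untested is made for them only; others in the source may bear on it.

Measured in an ADME assay on BJ cells (Homo sapiens) for cytotoxicity, read by luminescence, with a stated time of 72 h; a higher number here means that more compound is needed for the effect, a lower number that less compound is needed:
- Compound 1 `CCOC(=O)c1c(-c2cccc(-c3ccccc3)c2)[nH]c2cc(OC)ccc2c1=O`: > 21500 nM
- Compound 2 `CCOC(=O)c1c(-c2cccc(N(C)C)c2)[nH]c2cc(OC)ccc2c1=O`: > 21500 nM

Compound 1 stands at > 21500 nM, which is a limit and not a number. Compound 2 gives > 21500 nM, also a limit. Compound 3 `CCOC(=O)c1c(-c2cccc(-c3ccccc3)c2)[nH]c2cc(OC(C)C)ccc2c1=O` carries isopropoxy in place of methoxy: isopropyl in place of methyl on an oxygen on an aromatic ring. Within the data shown here, the only measured step, a step that the two limits leave unreadable from compound 1 to compound 2, changes a group on an aromatic carbon rather than on an oxygen, and its size cannot be read. Both values share one limit: the limit of > 21500 nM in this assay, at which 2 of the 2 values shown sit. No step beyond the scatter is therefore expected in this assay. The expected size is a step that the limit leaves unreadable from compound 1 to compound 3. Compound 3 is estimated at 25000 nM, with an expected range from 12000 nM to 50000 nM.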

Compound 3, half-maximal effective concentration: > 21500 nM
Compound 3 gave a limit, no number; the forecaster's own chance of this, stated with the estimate: 85%; the middle value does not contradict the limit.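

Among these compounds, compound 1 and compound 3 both give only a limit in this assay, so no step from methoxy to isopropoxy can be read: the limit of > 21500 nM in this assay, at which 3 of the 3 values shown sit. The compounds shown leave open what concentration of any of them reaches the half-maximal effect.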